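The source may hold more compounds than are shown below. What is called first, only, known or untested is meant among the compounds shown, and "the series" means these compounds.

Measured compounds:
compound 1 `O=C1/C(=C\c2ccc(O)cc2)c2ccccc2N1c1c(Cl)cccc1Cl` — 2 ug/mL
compound 2 `Cc1ccc2nc(Cl)c(/C=C3\C(=O)N(c4c(Cl)cccc4Cl)c4ccccc43)cc2c1` — 100 ug/mL

In a functional assay on KB cells (Homo sapiens) for cytotoxicity, read by MTT assay, with a stated time of 72 h (a lower number here means that less compound is needed, a higher number that more compound is needed for the effect), compound 1 gives 2 ug/mL, the lower of the two numbers. Compound 2 gives 100 ug/mL in this assay, a gap that lies well beyond the scatter. Compound 3 `COc1ccc(/C=C2\C(=O)N(c3c(Cl)cccc3Cl)c3ccccc32)cc1` differs from compound 1 by methyl in place of hydrogen on an oxygen on an aromatic ring. For the measured compounds named here, no measured pair shows this change, so the direction rests only on compound 1 and the small size of the change. The step of a 2.0-fold higher number from compound 1 to compound 3 (0.30 log units; within the scatter) is expected to be modest, barely beyond the scatter if at all. Compound 3 is estimated at 4 ug/mL in this assay, with a range from 1 ug/mL to 20 ug/mL.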

Compound 3, concentration for half-maximal effect: > 100 ug/mL
Compound 3 gave a limit, no number; the forecaster's own chance of this, stated with the estimate: 5%; middle value at least 25-fold (1.39 log units) away from the limit.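

In this assay compound 3 gives > 100 ug/mL as a limit of the assay, not a number. Going from 4-hydroxyphenyl to 4-methoxyphenyl gives an at least 50-fold higher number from compound 1 to compound 3 (1.69 log units; beyond the scatter) and shows that in this pair a single methyl on this oxygen is far from a small change. How large the step truly is cannot be read past that limit: the limit of > 100 ug/mL in this assay, at which 1 of the 3 values shown sits.

The compounds shown leave open whether a longer chain such as ethyl on this oxygen would behave like methyl. They also leave open what an amine or a carboxylic acid in place of the hydroxy would do.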